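The source may hold more compounds than are shown below. What is called first, only, known or untested is meant among the compounds shown, and "the series" means these compounds.

Working notes on the series.

The shared core, carrying a sulfonylated ring and an amide side chain, is tested in an in vitro functional assay on cells for antagonist activity at B1 bradykinin receptor (Homo sapiens), read by luminescence and calcium flux, with a stated time of 2 h; on this read-out higher numbers stand for weaker inhibition and lower numbers for stronger inhibition. Compound 1 `Cc1ccc(S(=O)(=O)N2C=CNC(=O)[C@H]2CC(=O)N[C@@H]2CCCc3cc(CN4CCCCC4)ccc32)cc1` gives 0.115 nM. Compound 3 `COc1ccc2c(c1)CCCC2NC(=O)C[C@@H]1C(=O)NC=CN1S(=O)(=O)c1ccc(C)cc1` gives 8.95 nM. Compound 2 `Cc1ccc(S(=O)(=O)N2C=CNC(=O)[C@H]2CC(=O)N[C@H](C)c2ccccc2)cc1` gives 836 nM, the highest of the three numbers; its nearest neighbour is compound 3, whose value lies far below it, and compound 1 lies further still, both gaps beyond the scatter. On these numbers compound 2 is the weakest inhibitor shown.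

Compound 4 `Cc1ccc(S(=O)(=O)N2C=CNC(=O)[C@H]2CC(=O)N[C@H]2CCN(C)CC2(C)C)cc1` has not yet been measured. Compared with compound 2, the change is a group of 9 heavy atoms (8 carbon, 1 nitrogen; one six-membered non-aromatic ring with 1 hetero atom) in place of a group of 8 heavy atoms (8 carbon; one six-membered aromatic ring of carbon only), on an amide-type nitrogen. Within the data shown here, no measured pair differs by this change alone, so no step size can be taken from the data. Compound 1, which also carries a nitrogen in a six-membered non-aromatic ring, shows the lowest number of the three, but its side chain differs from compound 4 in several other places, so this is no more than a hint.

The step from compound 2 to compound 4 is expected to be a 2.4-fold lower number from compound 2 to compound 4 (0.38 log units; beyond the scatter), towards a lower number, but with wide uncertainty. Compound 4 is estimated at 350 nM, within the range 50 nM to 3000 nM.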

Compound 4, half-maximal inhibitory concentration: 0.42 nM
Beside the measured number, compound 4's estimate is 830-fold (2.92 log units) above it; the measured number lies below the stated range.
By their numbers in this assay, from the lowest: compound 1; then compound 4; then compound 3; then compound 2.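

In this assay, among these compounds, the exchange on the amide-type nitrogen gives a 2000-fold lower number from compound 2 to compound 4 (3.30 log units; beyond the scatter) and so shows that this position, for which the earlier compounds offered no pair differing in one place, can carry a very large change in inhibition. The 1-phenylethyl group, with its six-membered aromatic ring of carbon only, is not required for strong inhibition in this series, since compound 4 gives 0.42 nM with a six-membered non-aromatic ring with 1 hetero atom in its place. Nothing measured here accounts for the size of this step.

The entering group differs from 1-phenylethyl in several features at once, namely the ring type, the ring nitrogen and the added hydrogen-bond acceptor, so the compounds shown leave open which of these features goes with the step. From the compounds shown here alone, a cyclohexyl group on the same amide-type nitrogen, or the entering ring without its methyl groups, would begin to separate these features, and the role of the single defined stereocentre in the entering group also remains open.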